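Aryl exchange on the carbonyl carbon: compound 3 to compound 4

The source may report more compounds than this note shows. Statements on the series, on what has been measured and on what is new or still open speak of the compounds shown alone.

Measured in a functional assay on UACC-257 cells (Homo sapiens) for cytotoxicity, read by sulforhodamine B assay, with a stated time of 48 h, tested at 0.01 uM (a lower number here means a stronger effect, a higher number a weaker effect of the compound at the concentration tested), so far:
compound 1, `COc1cc(-c2cc(/C=C/C(=O)c3ccc(Cl)c(Cl)c3)[nH]n2)cc(OC)c1OC`, gives 96%
compound 2, `COc1ccc(-c2cc(/C=C/C(=O)c3ccc(N)cc3)[nH]n2)cc1`, gives 96%
compound 3, `COc1ccc(C(=O)/C=C/c2cc(-c3cc(OC)c(OC)c(OC)c3)n[nH]2)cc1`, gives 97%

Compound 3 holds the highest of the three numbers, but all three lie within the scatter of one another, so no order can be read from them. Compound 4, `COc1cc(-c2cc(/C=C/C(=O)c3ccc(F)c(F)c3)[nH]n2)cc(OC)c1OC`, differs from compound 3 in one place: 3,4-difluorophenyl in place of 4-methoxyphenyl on a carbonyl carbon. Within the data shown here, the only step that bears on this place is the one from compound 1 to compound 3, a number 1 percentage points higher from compound 1 to compound 3 (within the scatter), which runs in the opposite direction and changed nothing beyond the scatter; compound 2 with yet another aryl on that carbonyl carbon gives a number in the same band. No step beyond the scatter is therefore expected here, a number 1 percentage points lower from compound 3 to compound 4 (within the scatter). Compound 4 is estimated at 96%, with a range from 90% to 101%.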

Compound 4, a percentage reported as activity, at one concentration (the size of the read-out at that concentration, not a potency): 88%
Beside the measured number, compound 4's estimate is 8 percentage points above it, and the stated range ends above it.
By their numbers in this assay, from the lowest: compounds 4, 1, 2 and 3 (each within the scatter of the next).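

In this assay, placing 3,4-difluorophenyl on the carbonyl carbon gives a number 9 percentage points lower from compound 3 to compound 4 (within the scatter), and the halogen exchange gives a number 8 percentage points lower from compound 1 to compound 4 (within the scatter). The 4-methoxyphenyl, 3,4-dichlorophenyl and 3,4-difluorophenyl groups at this place therefore remain unseparated at this single concentration, now across steps of larger size than the earlier one. No supporting data bear on this result.

Going by these compounds, whether a carboxylic acid on this aryl ring, or a longer chain in place of the ring, would give a step beyond the scatter remains open. Any difference among these compounds at other concentrations also remains open.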